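A few compounds are considered here, and "the series" means these few. Any claim that something is new, unique, unknown or untested is made for them only; others in the source may bear on it.

Measured in a functional assay on RS4-11 cells (Homo sapiens) for inhibition, read by CCK-8 assay, with a stated time of 48 h; a higher number here means a weaker inhibitor, a lower number a stronger inhibitor:
- Compound 1 `O=C(Nc1cccc([N+](=O)[O-])c1)N1CCN(S(=O)(=O)c2sccc2-c2ccccc2Oc2ccc(O)c(O)c2)CC1`: 9800 nM
- Compound 2 `O=C(NCCNS(=O)(=O)c1ccc(-c2ccccc2Oc2ccc([N+](=O)[O-])c([N+](=O)[O-])c2)s1)Nc1cc(Cl)cc(Cl)c1`: 2100 nM
- Compound 3 `COc1ccc(Oc2ccccc2-c2ccsc2S(=O)(=O)N2CCN(C(=O)Nc3cccc([N+](=O)[O-])c3)CC2)cc1OC`: > 50000 nM, a limit of the assay and not a number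

Among the two true numbers, compound 2 gives 2100 nM and compound 1 gives 9800 nM, so compound 1 is the weaker inhibitor of that pair. For the measured compounds named here, the two differ in more than one place, so they give no clean single step.

Compound 4 `O=S(=O)(c1sccc1-c1ccccc1Oc1ccc(O)c(O)c1)N1CCN(C(=S)Nc2ccc(Cl)cc2)CC1` departs from compound 1 in one place: a group of 10 heavy atoms (7 carbon, 1 nitrogen, 1 sulfur, 1 chlorine; one six-membered aromatic ring of carbon only) in place of a group of 12 heavy atoms (7 carbon, 2 nitrogen, 3 oxygen; one six-membered aromatic ring of carbon only), on an amine nitrogen in a ring. The (3-nitrophenyl)carbamoyl leaves, and the new group sits on the same amine nitrogen in a ring.

Going by the values given here, only one measured step starts from compound 1, and it is an at least 5.1-fold higher number from compound 1 to compound 3 (0.70 log units; beyond the scatter). There, 3,4-dimethoxyphenyl stands in place of 3,4-dihydroxyphenyl on an oxygen on an aromatic ring. Compound 4 keeps the 3,4-dihydroxyphenyl, so that step concerns a different part of the molecule and gives no size for this change. Among the compounds with values here, no measured step covers the amine nitrogen in a ring, so no shift in either direction can be predicted.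

The expected step, no larger than the scatter, is a 1.2-fold lower number from compound 1 to compound 4 (0.09 log units; within the scatter). For compound 4 the estimated value is 8000 nM, with an expected range from 2000 nM to 30000 nM.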

Compound 4, half-maximal inhibitory concentration: 7500 nM
Compound 4: middle estimate off by 1.1-fold (0.03 log units), on the high side; the measured number falls inside the stated range.
By their numbers in this assay, from the lowest: compound 2; then compounds 4 and 1 (each within the scatter of the next). At a limit, above all of these: compound 3.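

In this assay, putting the new group of 10 heavy atoms, with its sulfur and chlorine, in place of the (3-nitrophenyl)carbamoyl gives a 1.3-fold lower number from compound 1 to compound 4 (0.12 log units; within the scatter) and so leaves the two compounds indistinguishable. For the compounds shown here, this is the first measured step on the amine nitrogen in a ring, since the only earlier single step concerned the 3,4-dihydroxyphenyl, and it shows that this particular exchange of large groups at that position produces no difference beyond the scatter. Both groups carry a six-membered aromatic ring of carbon only and 1 hydrogen-bond donor, while the count of hydrogen-bond acceptors goes from 3 to 1, yet nothing measured here explains why compound 1 and compound 4 read alike.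

Several features differ at once in this one exchange, so the nitro group, the chlorine and the sulfur cannot be judged separately. On these data alone, it also stays open how the reading would respond to a much smaller group on the same nitrogen, such as an acetyl, or to a group bearing a carboxylic acid or an amine.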